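From Chloro to Cyano: Estimating Compound 4

This account rests on a few compounds, and the source may have more. Where it says the series, first, only, none or still open, it means among the compounds named here.

Of the compounds shown here, three sharing one core have been measured in an ADME assay on microsomes from liver (Rattus norvegicus) for metabolic stability, read by LC-MS, using NADPH, with stated times of 6 min and 10 min, tested at 0.5 uM; on this read-out higher numbers stand for a more stable compound and lower numbers for a less stable compound. Compound 1 `CC(=O)N1CCN(c2cc(C)cc(-c3cc(Cl)c4c(N)ncnn34)c2)C(=O)C1(C)C` gives 100%. Compound 2 `CC(=O)N1CCN(c2cc(-c3cc(Cl)c4c(N)ncnn34)ccc2C(F)(F)F)C(=O)C1(C)C` gives 87%. Compound 3 `CC(=O)N1CCN(c2cc(-c3cc(Cl)c4c(N)ncnn34)ccc2Cl)C(=O)C1(C)C` gives 52%, the lowest of the three numbers; its nearest neighbour is compound 2, and the step of a number 35 percentage points lower from compound 2 to compound 3 (beyond the scatter) lies beyond the scatter, while compound 1 stands further above it still.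

Compound 4 `CC(=O)N1CCN(c2cc(-c3cc(Cl)c4c(N)ncnn34)ccc2C#N)C(=O)C1(C)C` differs from compound 3 in one place: cyano in place of chloro on an aromatic carbon. For the measured compounds named here, no measured step exchanges chloro for cyano, so none bears on this change directly. Going by the values given here, the one step at this position, a number 35 percentage points lower from compound 2 to compound 3 (beyond the scatter), shows that a single swap of the group here can move this assay by a large amount, and the numbers of compounds 1, 2 and 3 show three different groups at this place giving widely spread values. Because compound 3 gives 52% and both other groups sit higher, compound 4 is expected to land somewhat higher, with an expected step of a number 16 percentage points higher from compound 3 to compound 4 (beyond the scatter). Compound 4 is estimated at 68%, within 40% to 92%.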

Compound 4, percent of the compound remaining: 89%
Beside the measured number, compound 4's estimate is 21 percentage points below it, within the range that was stated.
By their numbers in this assay, from the lowest: compound 3; then compounds 2 and 4 (each within the scatter of the next); then compound 1.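

In this assay, the exchange of chloro for cyano on this aromatic carbon, ortho to a large group and para to a large group, can now be read directly, and it is a large step (a number 37 percentage points higher from compound 3 to compound 4 (beyond the scatter)). The comparison with trifluoromethyl gives a step within the scatter (a number 2 percentage points higher from compound 2 to compound 4 (within the scatter)), so cyano and trifluoromethyl cannot be told apart at this place. Among compounds 2, 3 and 4, which differ only in this group, chloro alone stands apart, a picture that the single earlier step (a number 35 percentage points lower from compound 2 to compound 3 (beyond the scatter)) could not give.

Nothing presented here explains why chloro stands apart from the other two groups. Going by these compounds, it also remains open whether a methoxy group, a fluorine atom or an amine at this place would stay level with cyano and trifluoromethyl or fall towards chloro.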